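Replacing cyano with fluoro in compound 3

This account rests on a few compounds, and the source may have more. Where it says the series, first, only, none or still open, it means among the compounds named here.

Values so far in an ADME assay for permeability, using PAMPA; a lower number here means that the compound crosses the layer more slowly, a higher number that the compound crosses the layer faster
Compound 1 `O=C(Nc1ccccc1Cl)c1cc(Cl)ccc1O` gives 118 10^-6 cm/s
Compound 2 `O=C(Nc1ccc([N+](=O)[O-])c(Cl)c1)c1cc(Cl)ccc1O` gives 68 10^-6 cm/s
Compound 3 `N#Cc1ccc(NC(=O)c2cc(Cl)ccc2O)c(Cl)c1` gives 5.1 10^-6 cm/s

Compound 3 stands lowest of the three, and both other numbers lie well beyond the scatter above it. Compound 4 `O=C(Nc1ccc(F)cc1Cl)c1cc(Cl)ccc1O` has fluoro in place of cyano on an aromatic carbon. Within the data shown here, the one measured step that bears on this is a 23-fold lower number from compound 1 to compound 3 (1.36 log units; beyond the scatter) and it puts cyano in place of hydrogen at that same carbon. Taking the cyano away should therefore recover much of that drop, although no measured step shows what fluoro does here. The expected step is a 14-fold higher number from compound 3 to compound 4 (1.14 log units; beyond the scatter) and it would be large, towards a higher number in this assay as the direction. For compound 4 the estimated value is 70 10^-6 cm/s (expected range 25 10^-6 cm/s to 180 10^-6 cm/s).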

Compound 4, apparent permeability: 50.5 10^-6 cm/s
Beside the measured number, compound 4's estimate is 1.4-fold (0.14 log units) above it; measured number inside the range.
By their numbers in this assay, from the lowest: compound 3; then compounds 4, 2 and 1 (each within the scatter of the next, the first and the last beyond it).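

In this assay, fluoro in place of cyano brings a 9.9-fold higher number from compound 3 to compound 4 (1.00 log units; beyond the scatter), so the low number of compound 3 goes with the cyano, not with just any group on this aromatic carbon. Fluoro still leaves a mark, since putting it in place of hydrogen gives a 2.3-fold lower number from compound 1 to compound 4 (0.37 log units; beyond the scatter), a smaller step than the one cyano brings, a 23-fold lower number from compound 1 to compound 3 (1.36 log units; beyond the scatter). Nothing available explains why these two groups differ so much here. From the compounds shown here alone, whether an amine, a methoxy group or a carboxylic acid on this carbon would fall nearer compound 1 or compound 3 stays open.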